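A few compounds are considered here, and "the series" means these few. Any claim that something is new, unique, unknown or untested is made for them only; others in the source may bear on it.

Compound 1 `Cc1ccc([C@@H]2CC(=O)c3ccc(C)cc3O2)cc1`: 590 nM
Compound 2 `Cc1ccc(C2CC(=O)c3ccc(C)cc3O2)cc1`: 500 nM

In an in vitro assay on BTI-TN-5B1-4 cells for inhibition of Amine oxidase [flavin-containing] B (Homo sapiens) (a lower number here means a stronger inhibitor, a higher number a weaker inhibitor), the step of a 1.2-fold lower number from compound 1 to compound 2 (0.07 log units; within the scatter) lies within the scatter, so the two numbers cannot be told apart. Compound 3 `Cc1ccc([C@H]2CC(=O)c3ccc(C)cc3O2)cc1` has not yet been measured. It differs from compound 2 in one place: the two compounds have the same atoms and bonds; at least one stereo element is drawn with a configuration in one of them and without one in the other: 1 of 1 stereo elements differ; a stereocentre at a saturated ring carbon is drawn without a configuration in compound 2 and R in compound 3. Among the measured compounds shown here, the only measured step that bears on this change is a 1.2-fold lower number from compound 1 to compound 2 (0.07 log units; within the scatter), which concerned the same stereocentre and rests on (the fact that one of compounds 1 and 2 is drawn with a defined configuration and the other without, at the place where they differ). That step was within the scatter, so the expected step is a 1.1-fold lower number from compound 2 to compound 3 (0.05 log units; within the scatter), with nothing beyond the scatter. Compound 3 is therefore estimated at 450 nM, in a range from 200 nM to 1200 nM.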

Compound 3, half-maximal inhibitory concentration: 530 nM
The estimate for compound 3 lay 1.2-fold (0.07 log units) below the measured number; low and high end bracket the measured number.
By their numbers in this assay, from the lowest: compounds 2, 3 and 1 (each within the scatter of the next).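

With compound 3, the S and R drawings of the saturated ring carbon can be compared directly in this assay, and the step is a 1.1-fold lower number from compound 1 to compound 3 (0.05 log units; within the scatter), so the two configurations cannot be told apart here. The drawing without a configuration cannot be told apart from R either, with a step of a 1.1-fold higher number from compound 2 to compound 3 (0.03 log units; within the scatter). The first comparison is the cleanest test of this stereocentre, and its basis is this: the fact that compounds 1 and 3 differ only in the configuration as drawn

The compounds shown leave open whether configuration at this carbon would still make no measurable difference with other groups on the shared core. Replacing either methyl group with an amine or a carboxylic acid would test this.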